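A few compounds are considered here, and "the series" means these few. Any claim that something is new, unique, unknown or untested is made for them only; others in the source may bear on it.

Compounds 1, 2 and 3 share one core and differ only in the group attached to the chain. Compound 1 `O=S(=O)(NCCCNCc1ccc(Cl)c(Cl)c1)c1cc(C(F)(F)F)cc(C(F)(F)F)c1` gives 5600 nM in a functional assay on PANC-1 cells (Homo sapiens) for inhibition, read by MTT assay, with a stated time of 72 h; on this read-out lower numbers stand for stronger inhibition of growth and higher numbers for weaker inhibition of growth. Compound 2 `O=S(=O)(NCCCNCC1COc2ccccc2O1)c1cc(C(F)(F)F)cc(C(F)(F)F)c1` gives 3400 nM in this assay, and the change a 1.6-fold lower number from compound 1 to compound 2 (0.22 log units; within the scatter). Compound 3 `CN(CCCNS(=O)(=O)c1cc(C(F)(F)F)cc(C(F)(F)F)c1)Cc1ccccc1` reaches only a limit of this assay, reported as > 50000 nM. Compound 3 thus stands apart from the others: the change an at least 8.9-fold higher number from compound 1 to compound 3 (0.95 log units; beyond the scatter), and compound 3 sits at the limit of > 50000 nM in this assay, at which 1 of the 3 values shown sits.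

Compound 4 `COc1cccc(CNCCCNS(=O)(=O)c2cc(C(F)(F)F)cc(C(F)(F)F)c2)c1` is not yet measured. It differs from compound 3 in one place: (3-methoxybenzyl)amino in place of benzyl(methyl)amino on a saturated chain carbon, three bonds along the chain from a sulfonamide nitrogen. The methyl on the amine nitrogen goes, restoring the hydrogen-bond donor that compounds 1 and 2 carry, and a methoxy group enters on the benzyl ring. The step that bears most directly is an at least 8.9-fold higher number from compound 1 to compound 3 (0.95 log units; beyond the scatter), where losing that donor cost a great deal; the step of a 1.6-fold lower number from compound 1 to compound 2 (0.22 log units; within the scatter) shows that changing the aromatic piece on that carbon mattered little. A large drop in number is therefore expected in this assay, namely an at least 7.1-fold lower number from compound 3 to compound 4 (0.85 log units; beyond the scatter), back toward compounds 1 and 2. Compound 4 is expected to give about 7000 nM in this assay, with a range from 2500 nM to 25000 nM.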

Compound 4, concentration for 50% growth inhibition: 10000 nM
The estimate for compound 4 lay 1.4-fold (0.15 log units) below the measured number, and the stated range covers the measured number.
By their numbers in this assay, from the lowest: compounds 2, 1 and 4 (each within the scatter of the next, the first and the last beyond it). At a limit, above all of these: compound 3.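

In this assay, an at least 5.0-fold lower number from compound 3 to compound 4 (0.69 log units; beyond the scatter), so the benzyl-type group with an amine hydrogen recovers measurable growth inhibition even though its ring carries a methoxy group and no chlorine. The ring substituents are not wholly interchangeable, however: a 1.8-fold higher number from compound 1 to compound 4 (0.25 log units; within the scatter) cannot be told apart from no change, whereas a 2.9-fold higher number from compound 2 to compound 4 (0.47 log units; beyond the scatter) is a modest loss, a difference that the step between compound 1 and compound 2 alone could not reveal. The first of these steps rests on a value for compound 3 that is a limit and not a number: the limit of > 50000 nM in this assay, at which 1 of the 4 values shown sits.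

Compound 4 removes the methyl from the amine nitrogen and adds the methoxy group in a single step, so the compounds shown cannot assign the gain to either change, and a plain benzylamino group on the same chain would be needed to separate them. Also open, going by these compounds, is how the activity responds to a longer chain between the sulfonamide nitrogen and the amine, or to a carboxylic acid in place of the methoxy group.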